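The source may report more compounds than this note shows. Statements on the series, on what has been measured and on what is new or still open speak of the compounds shown alone.

Three compounds of one family were tested in an in vitro assay on BTI-TN-5B1-4 cells for inhibition of Amine oxidase [flavin-containing] A (Homo sapiens), read by Amplex Red, with a stated time of 15 min, tested at 100 uM; on this read-out lower numbers stand for less inhibition and higher numbers for more inhibition at the one concentration tested (going by the name of the read-out). Compound 1 `N#Cc1ccc(-c2csc(N/N=C\c3cccnc3)n2)cc1` gives 40% in this assay. Compound 2 `N#Cc1ccc(-c2csc(N/N=C\c3ccncc3)n2)cc1` is reported in this assay as "not active" (no number reported), with no number attached. Compound 3 `N#Cc1ccc(-c2csc(N/N=C\c3c[nH]c4ccccc34)n2)cc1` is likewise reported in this assay as "not active" (no number reported), again without a number. Compound 2 thus stands without a single number: where compound 1 has a figure, compound 2 has only the statement that nothing was seen, and compound 3 stands beside it in the same position.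

The step to be followed goes from compound 2 to compound 4 `Fc1ccc(-c2csc(N/N=C\c3ccncc3)n2)cc1`, which has not yet been measured. The change is fluoro in place of cyano on an aromatic carbon. Only this one part of the molecule is touched; the rest stays exactly as in compound 2.

Among the compounds with values here, no measured pair in this set shows what such a swap does to the read-out, so there is no step to lean on. With compound 2 showing no measurable inhibition, the starting point is low, and a change of one small group offers no direction that the numbers could support; a step beyond the scatter in this assay is not expected. Compound 4 is therefore estimated to show 12%, somewhere between 0% and 35%, with a fair chance that it too is simply reported as not active.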

Compound 4, a percentage reported as inhibition, at one concentration (the size of the read-out at that concentration, not a potency): 40%
Compound 4: the middle estimate sits 28 percentage points below what was measured, outside the stated range (above it).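

In this assay compound 2 has no number while compound 4 gives 40% and no step can be read between the two. Nothing shown here offers a reason for this result. The compounds shown leave open how much fluoro in place of cyano changes inhibition when both partners carry a number.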